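This account rests on a few compounds, and the source may have more. Where it says the series, first, only, none or still open, it means among the compounds named here.

In a functional assay on BT-549 cells (Homo sapiens) for cytotoxicity, read by MTT assay, with a stated time of 48 h (on this read-out higher numbers stand for weaker inhibition and lower numbers for stronger inhibition), compound 3 (`CC(C)n1c(/C=C2/C(=O)Nc3ccccc32)nc2ccccc21`) gives 38900 nM, the higher of the two exact numbers, and compound 1 (`CC(C)n1c(/C=C2/C(=O)Nc3ccc(Br)cc32)nc2ccccc21`) gives 13700 nM. Compound 2 (`CCn1c(/C=C2/C(=O)Nc3ccc(F)cc32)nc2ccccc21`), which has an ethyl chain and carries fluoro, reads > 50000 nM, and this is a limit of the assay, not a number.

Compound 4 (`CC(C)n1c(/C=C2/C(=O)Nc3ccc(F)cc32)nc2ccccc21`) keeps the isopropyl chain of compound 3 and makes one change, fluoro in place of hydrogen on an aromatic carbon. For the measured compounds named here, only one measured step bears on this directly, a 2.8-fold higher number from compound 1 to compound 3 (0.45 log units; beyond the scatter), which swaps bromo for hydrogen at the same place. Read backwards, that modest step says a halogen there lowers the number. Fluoro is a different halogen, though, so this single pair is a loose guide. A smaller shift in the same direction is expected, possibly one that stays within the usual scatter. The expected step is a 1.4-fold lower number from compound 3 to compound 4 (0.16 log units; within the scatter). For compound 4 the estimated value is 27000 nM, with an expected range from 12000 nM to 50000 nM.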

Compound 4, half-maximal inhibitory concentration: 26700 nM
The estimate for compound 4 lay 1.0-fold (0.00 log units) above the measured number; measured number inside the range.
By their numbers in this assay, from the lowest: compounds 1, 4 and 3 (each within the scatter of the next, the first and the last beyond it). At a limit, above all of these: compound 2.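

In this assay, there is a 1.5-fold lower number from compound 3 to compound 4 (0.16 log units; within the scatter), so the fluoro brings no clear change. Fluoro and bromo at this place also stay within the scatter of each other, with a 1.9-fold higher number from compound 1 to compound 4 (0.29 log units; within the scatter), so compound 4 cannot be separated from compound 1 or compound 3, and only the bromo compound stands clearly apart from the hydrogen compound. For the compounds shown here, the only step touching the chain is an at least 1.8-fold lower number from compound 2 to compound 4 (0.27 log units; that floor lies within the scatter), so it shows no clear effect of the chain. Compound 2 reads as a limit of the assay and not a number: the limit of > 50000 nM in this assay, at which 1 of the 4 values shown sits.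

Going by these compounds, what chloro, methoxy or an amine would do at this aromatic carbon remains open. So does the effect of a longer chain or a cyclopropyl group in place of the isopropyl chain.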